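From Compound 3 to Compound 4: One Further Chain Step

A few compounds are considered here, and "the series" means these few. Any claim that something is new, unique, unknown or untested is made for them only; others in the source may bear on it.

In a functional assay on HCT-116 cells (Homo sapiens) for cytotoxicity, read by MTT assay, with a stated time of 72 h (a higher number here means a weaker inhibitor, a lower number a stronger inhibitor), compound 1 (`[O-][S+](CCCCN=C=S)Cc1ccccc1`) gives 3660 nM, compound 2 (`[O-][S+](CCCN=C=S)Cc1ccccc1`) gives 15600 nM, and compound 3 (`[O-][S+](CCCCCN=C=S)Cc1ccccc1`) gives 5190 nM. Compound 3 therefore stands level with compound 1 within the scatter and clearly under compound 2, as the two measured steps show: a 1.4-fold higher number from compound 1 to compound 3 (0.15 log units; within the scatter) and a 3.0-fold lower number from compound 2 to compound 3 (0.48 log units; beyond the scatter). Among the measured compounds shown here, the third step, a 4.3-fold higher number from compound 1 to compound 2 (0.63 log units; beyond the scatter), is the only other comparison available in this short series.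

Compound 4 (`[O-][S+](CCCCCCN=C=S)Cc1ccccc1`) differs from compound 3 by a group of 4 heavy atoms (2 carbon, 1 nitrogen, 1 sulfur; no ring) in place of a group of 3 heavy atoms (1 carbon, 1 nitrogen, 1 sulfur; no ring), on a saturated chain carbon, five bonds along the chain from a sulfur. The change lies on a saturated chain carbon, five bonds along the chain from a sulfur. For the measured compounds named here, the closest precedent is the change from compound 1 to compound 3, made one position nearer the sulfur, and that step stayed within the scatter at a 1.4-fold higher number from compound 1 to compound 3 (0.15 log units; within the scatter). The larger steps involve only compound 2, so they say less about this end of the series. Going by the values given here, with only three measured compounds, no trend can be taken as settled. The estimated step is a 1.2-fold higher number from compound 3 to compound 4 (0.06 log units; within the scatter), and no change beyond the scatter is expected. For compound 4 the expected value is 6000 nM, with an estimated range from 2500 nM to 14000 nM.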

Compound 4, half-maximal inhibitory concentration: 11600 nM
For compound 4 the middle estimate is 1.9-fold (0.29 log units) below the measured one; the range from low to high includes it.
By their numbers in this assay, from the lowest: compounds 1 and 3 (each within the scatter of the next); then compounds 4 and 2 (each within the scatter of the next).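

In this assay, one further chain step at this position is no longer silent: a 2.2-fold higher number from compound 3 to compound 4 (0.35 log units; beyond the scatter), whereas the step on a saturated chain carbon, four bonds along the chain from a sulfur, was a 1.4-fold higher number from compound 1 to compound 3 (0.15 log units; within the scatter). The shortest and longest chains shown now stand level, a 1.3-fold lower number from compound 2 to compound 4 (0.13 log units; within the scatter), while the chain of compound 1 lies clear of the longest, a 3.2-fold higher number from compound 1 to compound 4 (0.50 log units; beyond the scatter), and the same lengthening gives different results at different chain lengths: the same change on two cores in this assay, a 3.0-fold lower number (0.48 log units; beyond the scatter) from compound 2 to compound 3 and a 3.2-fold higher number (0.50 log units; beyond the scatter) from compound 1 to compound 4, 9.5-fold (0.98 log units) apart, beyond the scatter of two such steps A single chain step likewise gives no fixed result, and its direction depends on the chain it is made on: the same change on two cores in this assay, a 4.3-fold higher number (0.63 log units; beyond the scatter) from compound 1 to compound 2 and a 2.2-fold lower number (0.35 log units; beyond the scatter) from compound 4 to compound 3, 9.5-fold (0.98 log units) apart, beyond the scatter of two such steps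

What the compounds shown leave open is whether a longer chain than that of compound 4 would carry the numbers further up, or whether they would settle at the level reached here. Also open is how an amine or a carboxylic acid would compare at this position, since every compound shown carries the same group on its chain.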